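The source may hold more compounds than are shown below. What is called first, only, known or untested is meant among the compounds shown, and "the series" means these compounds.

Cytotoxicity notes on a shared core. In a toxicity assay on L02 cells (Homo sapiens) for cytotoxicity, read by MTT assay, with a stated time of 72 h (on this read-out lower numbers stand for stronger inhibition and higher numbers for weaker inhibition), compound 2 `O=C1c2c[n+]([O-])c3ccccc3c2C(=O)c2[nH]c3ccccc3c21` gives 400 nM, the lowest number of the three shown, with compound 1 `CC1(C)O[C@@H](CO)[C@H](Cn2cc(Cn3c4c(c5ccccc53)C(=O)c3c[n+]([O-])c5ccccc5c3C4=O)nn2)O1` at 500 nM and compound 3 `O=C1c2c[n+]([O-])c3ccccc3c2C(=O)c2c1c1ccccc1n2Cc1cn([C@@H]2C[C@H](O)[C@@H](CO)O2)nn1` at 630 nM both within the scatter of it. Compound 4 `CN(C)CCCCn1c2c(c3ccccc31)C(=O)c1c[n+]([O-])c3ccccc3c1C2=O` differs from compound 2 in one place: 4-(dimethylamino)butyl in place of hydrogen on an aromatic nitrogen. For the measured compounds named here, the only measured step, a 1.3-fold higher number from compound 1 to compound 3 (0.10 log units; within the scatter), exchanges one group for another on the same aromatic nitrogen and lies within the scatter; the values of compound 1 and compound 3 set against compound 2 likewise show no shift beyond the scatter when a group occupies that nitrogen. A step within the scatter is therefore expected, a 1.1-fold higher number from compound 2 to compound 4 (0.05 log units; within the scatter). Compound 4 is estimated at 450 nM, within a range of 200 nM to 1100 nM.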

Compound 4, half-maximal inhibitory concentration: 300 nM
The estimate for compound 4 lay 1.5-fold (0.18 log units) above the measured number; low and high end bracket the measured number.
By their numbers in this assay, from the lowest: compounds 4, 2, 1 and 3 (each within the scatter of the next, the first and the last beyond it).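

In this assay, the step of a 1.3-fold lower number from compound 2 to compound 4 (0.12 log units; within the scatter) extends what was seen on this aromatic nitrogen to a substituent with no ring, whereas the groups in compound 1 and compound 3 both contain rings. A terminal dimethylamino group on a butyl chain therefore leaves the number within the scatter of compound 2, which carries hydrogen there. Nothing available explains this result.

The compounds shown leave open whether a shorter or longer chain would also stay within the scatter. They also leave open whether a primary amine or a carboxylic acid at the chain end would do so.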